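The compounds below may be only part of what the source reports. "The series", "measured", "known", "first", "only" and "open" are said of these compounds alone.

In a functional assay on RT-112 cells (Homo sapiens) for antiproliferative activity, read by MTT assay, with a stated time of 72 h (a lower number here means a stronger inhibitor of growth, a higher number a weaker inhibitor of growth), compound 1 (`COc1cc(Nc2ncnc3c(NC(=O)Nc4ccc(C)c(C)c4)cccc23)cc(OC)c1`) gives 8.8 nM. Compound 2 (`COc1cc(Nc2ncnc3c(NC(=O)Nc4cc(Cl)c(Cl)cc4Cl)cccc23)cc(OC)c1`), with a different group on the same amide-type nitrogen, gives 4890 nM. Compound 3 (`COc1cc(Nc2ncnc3c(NC(=O)Nc4ccc(Cl)c(C(F)(F)F)c4)cccc23)cc(OC)c1`), which carries a 4-chloro-3-(trifluoromethyl)phenyl group there, gives > 20000 nM, and this is a limit of the assay, not a number; it is the limit of > 20000 nM in this assay, at which 1 of the 3 values shown sits. Among these three, compound 3 stands at the weak end.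

Compound 4 (`COc1cc(Nc2ncnc3c(NC(=O)Nc4ccc(Cl)c(Cl)c4)cccc23)cc(OC)c1`) has not yet been measured. It differs from compound 3 in one place: chloro in place of trifluoromethyl on an aromatic carbon. Chloro takes the place of trifluoromethyl on an aromatic carbon, so 4-chloro-3-(trifluoromethyl)phenyl becomes 3,4-dichlorophenyl.

Going by the values given here, three measured steps bear on this change, all made on that same nitrogen. Two are large, a 560-fold higher number from compound 1 to compound 2 (2.74 log units; beyond the scatter) and an at least 2200-fold higher number from compound 1 to compound 3 (3.35 log units; beyond the scatter), and the third is at least modest, an at least 4.0-fold higher number from compound 2 to compound 3 (0.61 log units; beyond the scatter). Swapping this group can therefore move the number a long way. Compound 2, at 4890 nM, still gives a real number with only chloro groups on its ring, so a step to a lower number is expected in this assay.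

The estimated value for compound 4 is 800 nM, with an expected range from 40 nM to 12000 nM. That estimate means an at least 25-fold lower number from compound 3 to compound 4 (1.39 log units; beyond the scatter).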

Compound 4, concentration for 50% growth inhibition: 6230 nM
For compound 4 the middle estimate is 7.8-fold (0.89 log units) below the measured one; the measured number falls inside the stated range.
By their numbers in this assay, from the lowest: compound 1; then compounds 2 and 4 (each within the scatter of the next). At a limit, above all of these: compound 3.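

In this assay, chloro in place of trifluoromethyl brings the ring out of the range where no number can be read, with an at least 3.2-fold lower number from compound 3 to compound 4 (0.50 log units; beyond the scatter). Compound 3 stands at a limit of the assay and not at a number, so this step gives only a bound on the size of the change: the limit of > 20000 nM in this assay, at which 1 of the 4 values shown sits. The new compound also shows that the swap does not restore the strength of compound 1: taking one chloro off the trichlorophenyl ring leaves the reading within the scatter, with a 1.3-fold higher number from compound 2 to compound 4 (0.11 log units; within the scatter), while the two methyl groups and the two chloro groups stand far apart, with a 710-fold higher number from compound 1 to compound 4 (2.85 log units; beyond the scatter).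

The compounds shown leave open whether the low number of compound 1 needs both methyl groups, as no ring here carries one methyl group together with one chloro. They also leave open how this ring would read with a methoxy group or an amine on it, or with no group on it at all.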